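A few compounds are considered here, and "the series" means these few. Any claim that something is new, unique, unknown or untested is made for them only; others in the source may bear on it.

Of the compounds shown here, three that share one core have been tested so far. Compound 1 `NC(=O)c1c(NC(=O)c2ccccc2Cl)sc2c1CCN(C(=S)Nc1ccccc1C(F)(F)F)C2` gives 10600 nM in a functional assay on HL-60 cells (Homo sapiens) for antiproliferative activity, with a stated time of 24 h; a lower number here means a stronger inhibitor, a higher number a weaker inhibitor. Compound 2 `COc1ccccc1NC(=S)N1CCc2c(sc(NC(=O)c3ccccc3Cl)c2C(N)=O)C1` gives 40900 nM in this assay. Between them stands one change, (methoxy in place of trifluoromethyl on an aromatic carbon), and the step was a 3.9-fold higher number from compound 1 to compound 2 (0.59 log units; beyond the scatter). Compound 3 `COc1ccccc1NC(=S)N1CCc2c(sc(NC(=O)c3ccccc3C(F)(F)F)c2C(N)=O)C1` reaches only a limit of the measurement, > 50000 nM, in this assay; this is the limit of > 50000 nM in this assay, at which 1 of the 3 values shown sits. The step from compound 2 to compound 3 is an at least 1.2-fold higher number from compound 2 to compound 3 (0.08 log units; that floor lies within the scatter). The difference between the core of compound 1 and the core of compound 3 is not broken down here.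

Compound 4 `COc1ccccc1NC(=S)N1CCc2c(sc(NC(=O)c3ccccc3OC)c2C(N)=O)C1` has not yet been measured. It differs from compound 3 by methoxy in place of trifluoromethyl on an aromatic carbon, the same change that separates compound 1 from compound 2, though here it sits on the carbonyl-bearing ring rather than the amino-bearing one. Because the step of a 3.9-fold higher number from compound 1 to compound 2 (0.59 log units; beyond the scatter) gave a higher number, and because compound 3 already sits at a limit with > 50000 nM, the step that the limit leaves unreadable from compound 3 to compound 4 is expected to be a higher number again. Compound 4 is therefore estimated to give 90000 nM, between 30000 nM and 300000 nM, most likely reported only as a limit.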

Compound 4, half-maximal inhibitory concentration: > 50000 nM
Compound 4 ended at the assay's limit; the forecaster's own chance of this, stated with the estimate: 80%; the middle value does not contradict the limit.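

In this assay compound 4 gives > 50000 nM, which is a limit of the assay and not a number, and the step from compound 3 to compound 4 cannot be read, with both compounds at that limit: the limit of > 50000 nM in this assay, at which 2 of the 4 values shown sit.

Methoxy in place of trifluoromethyl on the other aromatic ring gave a 3.9-fold higher number from compound 1 to compound 2 (0.59 log units; beyond the scatter), but this result neither confirms nor rules out that the same change has a similar effect when moved to the ring on the carbonyl. On that carbonyl ring, methoxy in place of chloro gives an at least 1.2-fold higher number from compound 2 to compound 4 (0.08 log units; that floor lies within the scatter), so this step does not separate the two compounds.

From the compounds shown here alone, it remains open whether any group on the carbonyl ring, such as an amine or a carboxylic acid, would bring the number within the measurable range of this assay. Going by these compounds, it is also open how 2-methoxyphenyl on the carbonyl would read with 2-(trifluoromethyl)phenyl kept on the other side, as in compound 1.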